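Notes on nitrochromene amides: linker length and aryl removal

The source may report more compounds than this note shows. Statements on the series, on what has been measured and on what is new or still open speak of the compounds shown alone.

Measured so far:
compound 1 `CCOc1cc(NC(=O)CCCCCCC(=O)Nc2ccccc2N)cc2c1OCC([N+](=O)[O-])=C2`: 8630 nM
compound 2 `CCOc1cc(NC(=O)CCCCCCC(=O)Nc2cc(-c3ccc(C)s3)ccc2N)cc2c1OCC([N+](=O)[O-])=C2`: 6360 nM
compound 3 `CCOc1cc(NC(=O)CCCCCC(=O)Nc2cc(-c3ccc(C)s3)ccc2N)cc2c1OCC([N+](=O)[O-])=C2`: 11400 nM

All numbers come from a functional assay on PC-3 cells (Homo sapiens) for antiproliferative activity, read by MTT assay, with a stated time of 48 h; a higher number here means a weaker inhibitor of growth, a lower number a stronger inhibitor of growth. Compound 3 gives the highest number of the three, but its gaps to compound 1 and to compound 2 both lie within the scatter, so no order among the three compounds can be drawn. Compound 2 and compound 1 differ in one place, (hydrogen in place of 5-methylthiophen-2-yl on an aromatic carbon), and the step is a 1.4-fold higher number from compound 2 to compound 1 (0.13 log units; within the scatter).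

Compound 4 `CCOc1cc(NC(=O)CCCCCC(=O)Nc2ccccc2N)cc2c1OCC([N+](=O)[O-])=C2` is not yet measured in this assay. It differs from compound 3 by hydrogen in place of 5-methylthiophen-2-yl on an aromatic carbon, the same change made from compound 2 to compound 1, with the same surroundings of the place. The difference between the core of compound 3 and the core of compound 2 is not broken down here.

Taking the earlier step of a 1.4-fold higher number from compound 2 to compound 1 (0.13 log units; within the scatter) as the only guide, the expected step is a 1.3-fold higher number from compound 3 to compound 4 (0.12 log units; within the scatter), a small one. Compound 4 is estimated at 15000 nM in this assay, with a range from 7500 nM to 32000 nM; the measurement will show whether the removal behaves alike on the shorter chain.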

Compound 4, concentration for 50% growth inhibition: > 20000 nM
Compound 4: a limit, no number (the forecaster's own chance of this, stated with the estimate: 10%); middle value at least 1.3-fold (0.12 log units) away from the limit.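

In this assay compound 4 gives > 20000 nM, which is a limit of the assay and not a number. Hydrogen in place of 5-methylthiophen-2-yl on the shorter chain gives an at least 1.7-fold higher number from compound 3 to compound 4 (0.24 log units; that floor lies within the scatter), so the result does not conflict with the earlier step, and the direction could be the same on both cores. It does not show that the change carries over unaltered, nor that its size depends on the core: the same change on two cores in this assay, a 1.4-fold higher number (0.13 log units; within the scatter) from compound 2 to compound 1 and an at least 1.7-fold higher number (0.24 log units; that floor lies within the scatter) from compound 3 to compound 4; the limit leaves it open whether they differ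

As far as these compounds go, without the 5-methylthiophen-2-yl group, (2-aminophenyl)carbamoyl in place of ((2-aminophenyl)carbamoyl)methyl gives an at least 2.3-fold higher number from compound 1 to compound 4 (0.36 log units; beyond the scatter), whereas with that group compound 2 at 6360 nM and compound 3 at 11400 nM lie within the scatter of each other, so whether chain length matters only in the absence of the group stays open while compound 4 has no number. Also open, from the compounds shown here alone, is how a phenyl group or an unsubstituted thiophene at this place, or a longer chain, would read in this assay.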